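Piperidinyl in place of fluoroanilino on the quinone core

The source may hold more compounds than are shown below. What is called first, only, known or untested is meant among the compounds shown, and "the series" means these compounds.

Measured so far in a functional assay on HeLa cells (Homo sapiens) for inhibition, read by sulforhodamine B assay; a lower number here means a stronger inhibitor, a higher number a weaker inhibitor:
compound 1 `O=C1C(Nc2ccccc2F)=CC(=O)c2c1nc1n2[C@H]2OC[C@@H](O)[C@H]2OC1`: 9820 nM
compound 2 `O=C1C=C(Nc2ccccc2F)C(=O)c2c1nc1n2[C@H]2OC[C@@H](O)[C@H]2OC1`: 5120 nM
compound 3 `O=C1C(NCc2ccccc2)=CC(=O)c2c1nc1n2[C@H]2OC[C@@H](O)[C@H]2OC1`: 11000 nM

Compound 2 gives the lowest number of the three in this assay, but compound 1 sits within the scatter of it; only the gap to compound 3 lies beyond the scatter, so compound 2 cannot be called the strongest inhibitor on these numbers alone. The change to the unmeasured compound 4 `O=C1C=C(N2CCCCC2)C(=O)c2c1nc1n2[C@H]2OC[C@@H](O)[C@H]2OC1` is piperidin-1-yl in place of (2-fluorophenyl)amino on a double-bonded ring carbon. Within the data shown here, only one measured step touches the same position of the shared core: a 1.1-fold higher number from compound 1 to compound 3 (0.05 log units; within the scatter), which replaced one group on the amine nitrogen by another without any effect beyond the scatter. That step kept the amine hydrogen, whereas the move to compound 4 removes it together with the aromatic ring, so the comparison is indirect. Among the measured compounds shown here, with nothing among the measured compounds pointing to a shift in either direction, the expected step of a 1.3-fold higher number from compound 2 to compound 4 (0.10 log units; within the scatter) is no larger than the scatter, and compound 4 is estimated at 6500 nM, within 2500 nM to 17000 nM.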

Compound 4, half-maximal inhibitory concentration: > 16000 nM
Compound 4: only a limit was reported; the forecaster's own chance of this, stated with the estimate: 10%; middle value at least 2.4-fold (0.39 log units) from the limit.
By their numbers in this assay, from the lowest: compounds 2, 1 and 3 (each within the scatter of the next, the first and the last beyond it). At a limit, above all of these: compound 4.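

In this assay, among these compounds, the step of an at least 3.1-fold higher number from compound 2 to compound 4 (0.49 log units; beyond the scatter) is the first one-place change at this position to go beyond the scatter, whereas the earlier step of a 1.1-fold higher number from compound 1 to compound 3 (0.05 log units; within the scatter) stayed within it. The result therefore shows that the group on this double-bonded ring carbon can matter, and that piperidin-1-yl does not stand in for (2-fluorophenyl)amino here, although the change removes the amine hydrogen and the aromatic ring together. Compound 4 stands at a limit of the assay, not at a number: the limit of > 16000 nM in this assay, at which 1 of the 4 values shown sits.

The compounds shown do not separate the loss of the amine hydrogen from the loss of the aromatic ring. A methyl(phenyl)amino group would keep the ring without the hydrogen, and a cyclohexylamino group would keep the hydrogen without the aromatic ring.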